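Swapping Methyl for 4-Methylphenyl on a Carbonyl Carbon

The source may report more compounds than this note shows. Statements on the series, on what has been measured and on what is new or still open speak of the compounds shown alone.

Going by the values given here, in a functional assay, with a stated time of 30 min, in the absence of a further agent (on this read-out lower numbers stand for stronger inhibition and higher numbers for weaker inhibition), only two compounds have numbers so far. Compound 1 (`O=C(Nc1nnc(-c2cccc(O)c2O)s1)c1ccccc1`) gives 22300 nM, and compound 2 (`CC(=O)Nc1nnc(-c2cccc(O)c2O)s1`) gives 111000 nM. That is the higher number of the pair, which makes compound 2 the weaker inhibitor of the two.

The next compound, compound 3 (`Cc1ccc(C(=O)Nc2nnc(-c3cccc(O)c3O)s2)cc1`), keeps the core of compound 2 and changes a single group: 4-methylphenyl in place of methyl on a carbonyl carbon. Put simply, 4-methylphenyl stands in place of methyl on a carbonyl carbon.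

Among the compounds with values here, one measured step bears on this change. It is a 5.0-fold higher number from compound 1 to compound 2 (0.70 log units; beyond the scatter), a modest change that arose when methyl replaced phenyl on a carbonyl carbon. Within the data shown here, compound 3 goes the opposite way, back to a phenyl ring, but this ring also carries a methyl group, and no measurement yet shows what that extra methyl does. A move towards stronger inhibition therefore seems likely. The expected step is a 5.0-fold lower number from compound 2 to compound 3 (0.70 log units; beyond the scatter), similar in size to the measured one but towards a lower number. For compound 3 the estimate is 22000 nM, with an expected range of 9000 nM to 55000 nM.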

Compound 3, half-maximal inhibitory concentration: 27100 nM
Compound 3: middle estimate off by 1.2-fold (0.09 log units), on the low side, within the range that was stated.
By their numbers in this assay, from the lowest: compounds 1 and 3 (each within the scatter of the next); then compound 2.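

In this assay the change to 4-methylphenyl on a carbonyl carbon gives a 4.1-fold lower number from compound 2 to compound 3 (0.61 log units; beyond the scatter) and so repeats what phenyl did: two different rings at this place now both give stronger inhibition than methyl, where before there was only one. What is new is a direct reading of the extra methyl on the ring, which gives a 1.2-fold higher number from compound 1 to compound 3 (0.08 log units; within the scatter) and stays within the usual scatter, so compound 1 and compound 3 cannot be told apart. At this place, then, the clear difference lies between methyl and a ring, while adding a methyl to that ring leaves no change that can be distinguished from repeat variation.

The compounds shown leave open whether a ring is needed at all, since a longer chain such as butyl on the carbonyl carbon could sit anywhere relative to methyl and phenyl. They also leave open whether a group on the ring other than methyl, such as an amine or a carboxylic acid, would be as easily tolerated.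

No separate measurement is at hand that explains why a ring does better than methyl here.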